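Acetamido in Place of Dimethylamino on the Shared Core

The compounds below may be only part of what the source reports. "The series", "measured", "known", "first", "only" and "open" are said of these compounds alone.

Three measured compounds share one core and differ at a single aromatic carbon. In an assay on isolated protein for inhibition of serine/threonine-protein kinase TNNI3K (Homo sapiens) (a lower number here means a stronger inhibitor, a higher number a weaker inhibitor), compound 1 `CC(C)Nc1cc(Oc2ccc(NC(=O)Nc3cccc(C(F)(F)F)c3)cc2)ncn1` gives 40 nM, compound 2 `C[C@H](O)CNc1cc(Oc2ccc(NC(=O)Nc3cccc(C(F)(F)F)c3)cc2)ncn1` gives 32 nM, and compound 3 `CN(C)c1cc(Oc2ccc(NC(=O)Nc3cccc(C(F)(F)F)c3)cc2)ncn1` gives 2500 nM, the highest number of the three. The step of a 63-fold higher number from compound 1 to compound 3 (1.80 log units; beyond the scatter) and the step of a 78-fold higher number from compound 2 to compound 3 (1.89 log units; beyond the scatter) are both large, whereas a 1.3-fold lower number from compound 1 to compound 2 (0.10 log units; within the scatter) is not. Compound 4 `CC(=O)Nc1cc(Oc2ccc(NC(=O)Nc3cccc(C(F)(F)F)c3)cc2)ncn1` makes the change (acetamido in place of dimethylamino on an aromatic carbon); acetamido returns one hydrogen-bond donor to the position that dimethylamino left without one. The two large steps bear on this, so a lower number than that of compound 3 is expected, with caution since acetamido is not the isopropylamino or (2-hydroxypropyl)amino group already seen. Compound 4 is therefore estimated at 300 nM, between 60 nM and 1500 nM, an expected step of an 8.3-fold lower number from compound 3 to compound 4 (0.92 log units; beyond the scatter).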

Compound 4, half-maximal inhibitory concentration: 20 nM
Beside the measured number, compound 4's estimate is 15-fold (1.18 log units) above it, and the stated range ends above it.
By their numbers in this assay, from the lowest: compounds 4, 2 and 1 (each within the scatter of the next); then compound 3.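

Acetamido in place of dimethylamino gives a 130-fold lower number from compound 3 to compound 4 (2.10 log units; beyond the scatter), so this position accepts a carbonyl on the nitrogen and does not depend on an alkyl group there. Acetyl on this nitrogen gives a 1.6-fold lower number from compound 2 to compound 4 (0.20 log units; within the scatter) and a 2.0-fold lower number from compound 1 to compound 4 (0.30 log units; within the scatter), which places compounds 1, 2 and 4, all keeping a hydrogen on this nitrogen, apart from compound 3, which has none. No evidence is available to explain this difference.

Going by these compounds, whether that hydrogen is itself what matters remains open. So does how a free amine, a longer acyl chain or a methylsulfonylamino group would behave here.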